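Sulfonyl substituent and rat microsomal clearance in the series

This account rests on a few compounds, and the source may have more. Where it says the series, first, only, none or still open, it means among the compounds named here.

In an in vitro ADME assay on microsomes from liver (Rattus norvegicus) for metabolic stability, read by LC-MS, tested at 1 uM (a higher number here means faster removal of the compound, a lower number slower removal), compound 1 `COCCN(C)S(=O)(=O)c1ccc(C)c(C#Cc2cc(Cl)ccc2OCC(=O)O)c1` gives 49 mL.min-1.g-1. Compound 3 `Cc1ccc(S(C)(=O)=O)cc1C#Cc1cc(Cl)ccc1OCC(=O)O` gives 18 mL.min-1.g-1 in this assay, the lower of the two numbers shown. Compound 2 `COCCNS(=O)(=O)c1ccc(C)c(C#Cc2cc(Cl)ccc2OCC(=O)O)c1` reaches only a limit of the assay, < 10 mL.min-1.g-1. Compound 4 `Cc1ccc(S(=O)(=O)N(C)C)cc1C#Cc1cc(Cl)ccc1OCC(=O)O` carries dimethylamino in place of methyl on a sulfonyl sulfur. For the measured compounds named here, two measured steps bear on this: a 2.7-fold lower number from compound 1 to compound 3 (0.43 log units; beyond the scatter), and an at least 1.8-fold higher number from compound 2 to compound 3 (0.25 log units; that floor lies within the scatter), whose floor stays within the scatter. Further, an at least 4.9-fold lower number from compound 1 to compound 2 (0.69 log units; beyond the scatter), so the methyl on the sulfonamide nitrogen went with a higher number. Compound 4 shares that methyl on the sulfonamide nitrogen with compound 1, so a modest rise from compound 3 in this assay is expected, stopping short of compound 1. The expected step is a 1.6-fold higher number from compound 3 to compound 4 (0.19 log units; within the scatter). Compound 4 is therefore estimated at 28 mL.min-1.g-1, within 12 mL.min-1.g-1 to 60 mL.min-1.g-1.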

Compound 4, intrinsic clearance in microsomes: 22 mL.min-1.g-1
Beside the measured number, compound 4's estimate is 1.3-fold (0.10 log units) above it, and the stated range covers the measured number.
By their numbers in this assay, from the lowest: compounds 3 and 4 (each within the scatter of the next); then compound 1. At a limit, below all of these: compound 2.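

In this assay, dimethylamino and methyl on the sulfonyl sulfur cannot be told apart, with a 1.2-fold higher number from compound 3 to compound 4 (0.09 log units; within the scatter). A methyl on the sulfonamide nitrogen therefore does not by itself reach the level of compound 1, as a 2.2-fold lower number from compound 1 to compound 4 (0.35 log units; beyond the scatter) shows once the methoxymethyl is gone from the chain. The step of an at least 2.2-fold higher number from compound 2 to compound 4 (0.34 log units; beyond the scatter) starts from a limit of the assay, which belongs to compound 2: the limit of < 10 mL.min-1.g-1 in this assay, at which 1 of the 4 values shown sits.

Still open, on these data alone, is whether the number in compound 1 follows the ether oxygen or the chain length. A plain propyl chain, or a terminal amine on that chain, would separate these.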